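The source may report more compounds than this note shows. Statements on the series, on what has been measured and on what is new or still open speak of the compounds shown alone.

In a functional assay on KYSE-410 cells (Homo sapiens) for antiproliferative activity, read by MTT assay, with a stated time of 72 h (on this read-out lower numbers stand for stronger inhibition and higher numbers for weaker inhibition), compound 1 (`O=C(Nc1cccc(F)c1)c1cc(=O)[nH]c2cc(Br)ccc12`) gives 7300 nM and compound 3 (`O=C(Nc1cc(F)cc(F)c1)c1cc(=O)[nH]c2cc(Br)ccc12`) gives 11200 nM in a pair that lies within the scatter. Compound 2 (`O=C(Nc1cccc(Cl)c1)c1cc(=O)[nH]c2cc(Br)ccc12`) gives only a limit (> 20000 nM) in the same test. Compound 4 (`COc1ccc(-c2ccc3c(C(=O)Nc4cccc(F)c4)cc(=O)[nH]c3c2)cc1`) differs from compound 1 by 4-methoxyphenyl in place of bromo on an aromatic carbon and has 4-methoxyphenyl in place of bromo on an aromatic carbon. Only changes on the fluoro-bearing ring have been measured: a 1.5-fold higher number from compound 1 to compound 3 (0.19 log units; within the scatter) and an at least 2.7-fold higher number from compound 1 to compound 2 (0.43 log units; beyond the scatter). Neither touches the bromo position, so they offer a scale only. A modest move toward stronger inhibition is expected in this assay, estimated as a 2.4-fold lower number from compound 1 to compound 4 (0.39 log units; beyond the scatter) with wide uncertainty. The estimate for compound 4 is 3000 nM, with an expected range of 500 nM to 15000 nM here.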

Compound 4, half-maximal inhibitory concentration: 18000 nM
Beside the measured number, compound 4's estimate is 6.0-fold (0.78 log units) below it; the whole stated range lies below it.
By their numbers in this assay, from the lowest: compounds 1, 3 and 4 (each within the scatter of the next, the first and the last beyond it). At a limit, above all of these: compound 2.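

The bromo position is not silent: in this assay, 4-methoxyphenyl in place of bromo gives a 2.5-fold higher number from compound 1 to compound 4 (0.39 log units; beyond the scatter), so this added aromatic ring brings no gain over bromo. Compound 4 still gives a number, but the readable range of the test ends not far above it, and compound 2 is recorded only as a limit: the limit of > 20000 nM in this assay, at which 1 of the 4 values shown sits.

A single aryl group cannot separate the effect of the ring from that of its methoxy group. Going by these compounds, whether plain phenyl, an amine or a carboxylic acid at this position would lower the number remains open.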